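Replacing 4-methoxyphenyl with 2,3-dichlorophenyl in compound 3

The source may report more compounds than this note shows. Statements on the series, on what has been measured and on what is new or still open speak of the compounds shown alone.

compound 1 `COc1cc(O)c(C(=O)/C=C/c2ccc(OC)c(OC)c2)c(OC)c1` gives 27600 nM
compound 2 `COc1cc(O)c(C(=O)/C=C/c2ccc(F)cc2)c(OC)c1` gives 4400 nM
compound 3 `COc1ccc(/C=C/C(=O)c2c(OC)cc(OC)cc2OCC=C(C)C)cc1` gives 7600 nM

In a functional assay on HCT-116 cells (Homo sapiens) for antiproliferative activity, read by sulforhodamine B assay, with a stated time of 48 h (on this read-out lower numbers stand for stronger inhibition and higher numbers for weaker inhibition), compound 3 gives 7600 nM, a number within the scatter of compound 2 and clearly lower than that of compound 1. Compound 4 `COc1cc(OC)c(C(=O)/C=C/c2cccc(Cl)c2Cl)c(OCC=C(C)C)c1` has not yet been measured. It carries 2,3-dichlorophenyl in place of 4-methoxyphenyl on a double-bonded chain carbon bound to a double-bonded chain carbon.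

For the measured compounds named here, no measured pair shows this change on its own. Compound 2, whose aryl ring bears fluorine, gives 4400 nM, while compound 1, with two methoxy groups on that ring, gives 27600 nM. This offers only a weak hint that a halogenated ring may be tolerated, and three compounds cannot establish a pattern. The expected change is therefore small, a 1.5-fold lower number from compound 3 to compound 4 (0.18 log units; within the scatter) in this assay, toward a lower number and within the scatter. For compound 4 the estimated value is 5000 nM, with an expected range from 1700 nM to 15000 nM.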

Compound 4, half-maximal inhibitory concentration: 1900 nM
For compound 4 the middle estimate is 2.6-fold (0.42 log units) above the measured one; measured number inside the range.
By their numbers in this assay, from the lowest: compound 4; then compounds 2 and 3 (each within the scatter of the next); then compound 1.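

For the compounds shown here, exchanging 4-methoxyphenyl for 2,3-dichlorophenyl on a double-bonded chain carbon bound to a double-bonded chain carbon gives, in this assay, a 4.0-fold lower number from compound 3 to compound 4 (0.60 log units; beyond the scatter), the first single change in this set that can be read on its own. Where the earlier compounds differed in more than one place, this pair shows directly that the group at this position affects the antiproliferative read-out and that 4-methoxyphenyl is not required there. No supporting data explain the step, and it cannot separate the entry of the two chlorines from the loss of the methoxy group.

Going by these compounds, whether a single chlorine, or a trifluoromethyl group or an amine on the same ring, would give a similar number remains open. So does whether this exchange would carry over to the core of compound 2.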